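Benzylamino replaces a selenium chain on the shared core

This account rests on a few compounds, and the source may have more. Where it says the series, first, only, none or still open, it means among the compounds named here.

Growth inhibition is read in a functional assay on CCRF-CEM cells (Homo sapiens) for cytotoxicity, read by MTT assay, with a stated time of 72 h; a lower number here means a stronger inhibitor of growth, a higher number a weaker inhibitor of growth. Compound 1 `CCCCC[Se]c1nc(N)c2ccccc2n1` carries one group of 6 heavy atoms (5 carbon, 1 selenium; no ring) and an amino group on the shared core; in this assay compound 1 gives 68000 nM. Compound 2 `C[Se]c1nc(N)c2cccnc2n1` has a methyl on the selenium and a core with a further ring nitrogen. In this assay compound 2 stops at > 100000 nM, which is a limit of the assay and not a number. Compound 3 `CCCCC[Se]c1nc([Se]CCCCC)c2ccccc2n1` carries two of the selenium-bearing groups. In this assay compound 3 likewise stands at > 100000 nM, again a limit and not a number. For the measured compounds named here, compound 3 therefore sits at the limit of > 100000 nM in this assay, at which 2 of the 3 values shown sit, and the single measured step that leads to it, an at least 1.4-fold higher number from compound 1 to compound 3 (0.16 log units; that floor lies within the scatter), has a floor lying within the scatter.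

Compound 4 `CCCCC[Se]c1nc(NCc2ccccc2)c2ccccc2n1` differs from compound 3 by a group of 8 heavy atoms (7 carbon, 1 nitrogen; one six-membered aromatic ring of carbon only) in place of a group of 6 heavy atoms (5 carbon, 1 selenium; no ring), on an aromatic carbon. The step from compound 1 to compound 3 is the only one that bears on this change, and it removed a hydrogen-bond donor; compound 4 brings 1 hydrogen-bond donor back, so a move towards a lower number in this assay is expected, though a shift no larger than the scatter cannot be ruled out. The expected step is an at least 3.3-fold lower number from compound 3 to compound 4 (0.52 log units; beyond the scatter), with compound 1 at 68000 nM as the nearest measured anchor. Compound 4 is expected at 30000 nM, within 8000 nM to 100000 nM.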

Compound 4, concentration for total growth inhibition: 72500 nM
For compound 4 the middle estimate is 2.4-fold (0.38 log units) below the measured one, and the stated range covers the measured number.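

At this position, on an aromatic carbon next to the ring nitrogen, the benzylamino group of compound 4 and the amino group of compound 1 cannot be told apart in this assay, where benzyl in place of hydrogen on the nitrogen gives a 1.1-fold higher number from compound 1 to compound 4 (0.03 log units; within the scatter) and so adds nothing that can be read over the plain amino group in this one pair. Exchanging the selenium-bearing group for benzylamino gives an at least 1.3-fold lower number from compound 3 to compound 4 (0.13 log units; that floor lies within the scatter), and with a floor inside the scatter no size can be put on this change, nor can a real difference be claimed. Compound 3 stays a limit of the assay and not a number: the limit of > 100000 nM in this assay, at which 2 of the 4 values shown sit.

Still open, from the compounds shown here alone, is whether another group on this nitrogen, such as a butyl chain, a phenethyl group or a chain ending in a carboxylic acid, would move the number beyond the scatter. Also open, going by these compounds, is what the selenium-bearing group that remains in compound 1 and compound 4 contributes, which a shorter or longer chain on the selenium, with the benzylamino group kept in place, would address.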